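The source may report more compounds than this note shows. Statements on the series, on what has been measured and on what is new or still open speak of the compounds shown alone.

Measured compounds:
compound 1 `Cn1c(Cc2nn(C)c(=O)c3ccccc23)nnc1SCCCCCCCC(=O)Nc1ccc(Cl)cc1Cl` — 350 nM
compound 2 `CN(C)CCCn1c(Cc2nn(C)c(=O)c3ccccc23)nnc1SCCCCCCCC(=O)Nc1ccc(Cl)cc1Cl` — > 30000 nM

Of the compounds shown here, two have been tested in an assay on NK92 cells for inhibition of interleukin-2 (Homo sapiens), read by AlphaScreen, with stated times of 30 min and 1 h; a lower number here means a stronger inhibitor, a higher number a weaker inhibitor. Among the compounds with values here, compound 1 gives 350 nM, the only number so far. Compound 2 shows no number at all but only > 30000 nM, which is a limit of the measurement (the limit of > 30000 nM in this assay, at which 1 of the 2 values shown sits). Within the data shown here, the one step between them, an at least 85-fold higher number from compound 1 to compound 2 (1.93 log units; beyond the scatter), is therefore a large loss in potency, though its true size is unknown.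

Compound 3 `Cn1c(Cc2nn(CCC=O)c(=O)c3ccccc23)nnc1SCCCCCCCC(=O)Nc1ccc(Cl)cc1Cl` has not yet been measured. It differs from compound 1 by formylmethyl in place of hydrogen on a saturated chain carbon bound to an aromatic nitrogen; read one bond further out, the methyl becomes a 2-formylethyl. Among the measured compounds shown here, the only measured step that bears on this change is an at least 85-fold higher number from compound 1 to compound 2 (1.93 log units; beyond the scatter), where a 2-(dimethylamino)ethyl also grew out of a hydrogen on a saturated chain carbon bound to an aromatic nitrogen and the potency collapsed. The entering group here is smaller and different in kind, so the same outcome is not certain, but a loss is the more likely direction. Compound 3 is therefore expected to give 1500 nM, plausibly between 300 nM and 15000 nM, an expected step of a 4.3-fold higher number from compound 1 to compound 3 (0.63 log units; beyond the scatter).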

Compound 3, half-maximal inhibitory concentration: 21900 nM
The estimate for compound 3 lay 15-fold (1.16 log units) below the measured number, outside the stated range (above it).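

Growing the methyl into a 2-formylethyl costs much of the potency in this assay, with a 63-fold higher number from compound 1 to compound 3 (1.80 log units; beyond the scatter). This is not the methyl that was extended in compound 2, so growth at either of the two methyl groups that compound 1 carries on an aromatic nitrogen has now gone with a large loss, and the new loss comes with a group that holds a formyl rather than an amine; compound 3 also gives a true number, so the size of this loss can be read. Compound 2 gives only a limit of the assay and not a number: the limit of > 30000 nM in this assay, at which 1 of the 3 values shown sits.

The compounds shown do not separate the length of the new chain from the formyl group at its end: a plain propyl, or a 2-carboxyethyl with a carboxylic acid in place of the formyl, would help tell these two apart. They also leave open how small an addition this position accepts, a question that a single ethyl on the same nitrogen would begin to answer.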